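The compounds below may be only part of what the source reports. "The series", "measured", "known", "first", "only" and "open" are said of these compounds alone.

Three compounds from this series carry entries in a functional assay on MCF7 cells (Homo sapiens) for cytotoxicity, read by MTT assay, with a stated time of 72 h (on this read-out higher numbers stand for weaker inhibition and lower numbers for stronger inhibition), and one more awaits its turn. Compound 1 `CS(=O)(=O)NCCCN(c1nc(C(=O)NCc2ccc(F)cc2)c(O)c2ncccc12)S(C)(=O)=O` returns only a limit of the assay in this assay, > 20000 nM, which is the point described by the limit of > 20000 nM in this assay, at which 1 of the 3 values shown sits. Compound 3 `N[C@H]1CC[C@H](NC(=O)c2nc(Br)c3cccnc3c2NCc2ccc(F)cc2)CC1` has no result in this assay: "not determined" (no result reported). Among the compounds with values here, compound 2 `N[C@H]1CC[C@H](Nc2c(C(=O)NCc3ccccn3)nc(Br)c3cccnc23)CC1` is therefore the only compound with a plain number in this assay, where compound 2 gives 15000 nM. It stands alone in that respect, as neither of the other two entries adds a second plain number.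

Compound 4 `N[C@H]1CC[C@H](Nc2c(C(=O)NC3CCCCC3)nc(Br)c3cccnc23)CC1` differs from compound 2 at a single place: cyclohexyl in place of (pyridin-2-yl)methyl on an amide-type nitrogen. Within the data shown here, no step between two measured compounds is available to gauge the size of such an exchange. The step from compound 2 to compound 4 is expected to stay within the scatter of this assay, or to move modestly toward weaker inhibition, a 1.2-fold higher number from compound 2 to compound 4 (0.08 log units; within the scatter). Compound 4 is accordingly estimated at 18000 nM in this assay, with a range from 6000 nM to 50000 nM.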

Compound 4, half-maximal inhibitory concentration: 5200 nM
Compound 4: middle estimate off by 3.5-fold (0.54 log units), on the high side, and the stated range ends above it.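

The exchange of (pyridin-2-yl)methyl for cyclohexyl on the amide-type nitrogen gives a 2.9-fold lower number from compound 2 to compound 4 (0.46 log units; beyond the scatter) in this assay, the first sign in the series that this position affects the reading. Compound 4 has no aromatic ring and no hydrogen-bond acceptor in this group, yet the number falls rather than rises, so neither feature of the (pyridin-2-yl)methyl group is needed here for the inhibition seen with compound 2. Nothing measured in the study accounts for the size or direction of this step.

The exchange alters the ring type, the ring nitrogen and the link to the amide at once, and these compounds do not separate those changes. A benzyl or cyclohexylmethyl group on the same nitrogen would help to tell them apart.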